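A methylpiperazine side chain in place of piperidine

This account rests on a few compounds, and the source may have more. Where it says the series, first, only, none or still open, it means among the compounds named here.

Values in an ADME assay on microsomes from liver (Mus musculus) for metabolic stability, read by LC-MS, with a stated time of 10 min, tested at 0.5 uM (a lower number here means that less of the compound is left, a higher number that more of the compound is left), for the three measured compounds
- compound 1 `c1ccc2c(c1)CN[C@@H](CN(CCCN1CCNCC1)[C@H]1CCCc3cccnc31)C2` gives 92%
- compound 2 `c1ccc2c(c1)CN[C@@H](CN(CC[C@@H]1CCCNC1)[C@H]1CCCc3cccnc31)C2` gives 23%
- compound 3 `c1ccc2c(c1)CN[C@@H](CN(CC[C@H]1CCCNC1)[C@H]1CCCc3cccnc31)C2` gives 56%

Compound 3 sits in the middle of these three numbers, below compound 1 and above compound 2. The number is a number 33 percentage points higher from compound 2 to compound 3 (beyond the scatter) due to the fact that compounds 2 and 3 differ only in the configuration as drawn and this shows how much the drawn configuration alone can matter here.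

Compound 4 `CN1CCN(CCCN(C[C@H]2Cc3ccccc3CN2)[C@H]2CCCc3cccnc32)CC1` changes one group of compound 3 on the shared core ((4-methylpiperazin-1-yl)methyl in place of piperidin-3-yl on a saturated chain carbon, two bonds along the chain from an amine nitrogen), placing (4-methylpiperazin-1-yl)methyl where piperidin-3-yl stood.

The most useful guides are two measured steps at this same place, where piperidin-3-yl replaced (piperazin-1-yl)methyl. One gave a number 36 percentage points lower from compound 1 to compound 3 (beyond the scatter) and the other gave a number 69 percentage points lower from compound 1 to compound 2 (beyond the scatter) as the result. Both were large falls. Compound 4 keeps the piperazine ring, so running the step of a number 36 percentage points lower from compound 1 to compound 3 (beyond the scatter) backwards suggests a rise in this assay of clear size, though one kept short of the full gap. For the measured compounds named here, no measured compound carries the added methyl.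

The expected change is a number 20 percentage points higher from compound 3 to compound 4 (beyond the scatter) in this estimate. For compound 4 an estimated 76% is expected, with 52% and 96% as the expected ends of the range.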

Compound 4, percent of the compound remaining: 53%
Compound 4: the middle estimate sits 23 percentage points above what was measured; the measured number falls inside the stated range.
By their numbers in this assay, from the lowest: compound 2; then compounds 4 and 3 (each within the scatter of the next); then compound 1.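

At this position, the swap to (4-methylpiperazin-1-yl)methyl from piperidin-3-yl does not by itself bring back the high number of compound 1: in this assay the outcomes are small in one case (a number 3 percentage points lower from compound 3 to compound 4 (within the scatter)) and modest in the other (a number 30 percentage points higher from compound 2 to compound 4 (beyond the scatter)). The same change of group reads differently against the two piperidine partners, because the starting points themselves are far apart: the fact that compounds 2 and 3 differ only in the configuration as drawn. For the compounds shown here, the new information lies in the methyl on the amine nitrogen in a ring, the only change in a pair that gives a large fall in this assay (a number 39 percentage points lower from compound 1 to compound 4 (beyond the scatter)), so the piperazine ring alone does not secure a high number here.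

Going by these compounds, whether a methyl on the ring nitrogen of compound 2 or compound 3 would also lower the number stays open, as does whether an ethyl or an acetyl group on the piperazine nitrogen would behave like the methyl. This single pair also cannot say what lies behind the fall, or whether it would persist with a longer chain.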